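The source may hold more compounds than are shown below. What is called first, only, known or untested is meant among the compounds shown, and "the series" means these compounds.

Measured compounds:
Compound 1 `CN1CCN(c2ccc(Nc3nc(-c4cccc(NC(=O)c5ccccc5)c4)sc3C(=O)O)cc2)CC1` gives 26.3% in a functional assay on Ramos cells (Homo sapiens) for antiproliferative activity, read by CCK-8 assay, with a stated time of 72 h, tested at 40 uM; a lower number here means less inhibition, a higher number more inhibition at the concentration tested (going by the name of the read-out).
Compound 2 `CN1CCN(c2ccc(Nc3nc(-c4cccc(NC(=O)c5ccc(F)c(Cl)c5)c4)sc3C(=O)O)cc2)CC1` gives 98.6% in this assay.

Compound 1 stands lowest of the two numbers; its nearest neighbour is compound 2, and the change from one to the other, a number 72.3 percentage points higher from compound 1 to compound 2 (beyond the scatter), lies beyond the scatter. That step, however, alters the group on the other carbonyl carbon of the shared core and says nothing about the acid end.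

Compound 3 `CN1CCN(c2ccc(Nc3nc(-c4cccc(NC(=O)c5ccccc5)c4)sc3C(N)=O)cc2)CC1` differs from compound 1 only there: amino in place of hydroxy on a carbonyl carbon. Among the measured compounds shown here, no measured pair shows this change, so there is no step to lean on. Without such guidance the plain expectation is a step in this assay that stays within the scatter, a number 3.7 percentage points higher from compound 1 to compound 3 (within the scatter), in no firm direction. Compound 3 is therefore estimated at 30%, with a range from 10% to 60%.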

Compound 3, a percentage reported as inhibition, at one concentration (the size of the read-out at that concentration, not a potency): 98.1%
Compound 3: the middle estimate sits 68.1 percentage points below what was measured; measured number outside the range, above it.
By their numbers in this assay, from the lowest: compound 1; then compounds 3 and 2 (each within the scatter of the next).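

The acid end of the shared core turns out to matter as well: in this assay, carbamoyl in place of carboxy gives a number 71.8 percentage points higher from compound 1 to compound 3 (beyond the scatter) and involves only the exchange of hydroxy for amino on a carbonyl carbon. The counts of heavy atoms, hydrogen-bond donors and hydrogen-bond acceptors stay the same in this swap, so this position responds strongly to a change that leaves those counts untouched, which compound 1 and compound 2 could not show, as they differ only at the other carbonyl carbon. No measurement shown here accounts for the size of this step.

On these data alone, whether a methyl ester or a nitrile at this place would behave like the carbamoyl group remains open. Also open, as far as these compounds go, is how carbamoyl behaves when the other carbonyl carbon carries 3-chloro-4-fluorophenyl.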